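The source may hold more compounds than are shown below. What is called first, only, known or untested is meant among the compounds shown, and "the series" means these compounds.

In a functional assay on HCT-116 cells (Homo sapiens) for antiproliferative activity, read by MTT assay, with a stated time of 72 h (on this read-out lower numbers stand for stronger inhibition and higher numbers for weaker inhibition), compound 2 `CCC(=O)NNC(=O)c1csc2ncc(-c3ccc(C)cc3)n12` gives 9230 nM. Going by the values given here, compound 1 `COc1ccc(NC(=S)Nc2nc(C(=O)NCc3ccccc3)cs2)cc1` gives 18200 nM, a value within the scatter of the one for compound 2. Among the compounds with values here, compound 3 `CCCC(=O)NNC(=O)c1csc2ncc(-c3ccc(C)cc3)n12` gives 34500 nM, and the one measured step among the close relatives is a 3.7-fold higher number from compound 2 to compound 3 (0.57 log units; beyond the scatter), a modest step beyond the scatter, made on a saturated chain carbon. Compound 4 `CCC(=O)NNC(=O)c1csc2ncc(-c3ccc(OC)cc3)n12` differs from compound 2 elsewhere: methoxy in place of methyl on an aromatic carbon. Within the data shown here, no measured step touches that aromatic ring, so the chain step offers no direct guide, and no step beyond the scatter is expected in this assay. The estimated step is a 1.1-fold higher number from compound 2 to compound 4 (0.03 log units; within the scatter). Compound 4 is expected to give 10000 nM, with an estimated range from 3500 nM to 28000 nM.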

Compound 4, half-maximal inhibitory concentration: 64300 nM
For compound 4 the middle estimate is 6.4-fold (0.81 log units) below the measured one; the whole stated range lies below it.
By their numbers in this assay, from the lowest: compounds 2, 1, 3 and 4 (each within the scatter of the next, the first and the last beyond it).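

In this assay, going by these compounds alone, the change from 4-methylphenyl to 4-methoxyphenyl gives a 7.0-fold higher number from compound 2 to compound 4 (0.84 log units; beyond the scatter), so the aromatic carbon, which no earlier step touched, is sensitive to what it carries. This step lies beyond the scatter, as does the chain step a 3.7-fold higher number from compound 2 to compound 3 (0.57 log units; beyond the scatter), so both places on compound 2 affect the number. Nothing at hand explains why methoxy behaves this way here. The compounds shown leave open how a hydrogen, a chlorine or an amine at this carbon would compare with methyl. They also leave open whether the same change would give a similar step on compound 3.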